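Changing the Ring on the Amine Nitrogen: an Expectation

The source may hold more compounds than are shown below. What is called first, only, known or untested is meant among the compounds shown, and "the series" means these compounds.

Compound 1 `COc1ccc(OC)c(Nc2nc(/C=C/c3ccccc3OC(C)=O)nc3ccccc23)c1`: 7840 nM
Compound 2 `COc1ccccc1/C=C/c1nc(Nc2ccccc2Cl)c2ccccc2n1`: 18900 nM

In a functional assay on MCF7 cells (Homo sapiens) for antiproliferative activity, with a stated time of 72 h (on this read-out higher numbers stand for weaker inhibition and lower numbers for stronger inhibition), compound 2 gives the highest of the two numbers measured, and the gap to compound 1 lies beyond the usual scatter. Compound 3 `COc1ccccc1/C=C/c1nc(Nc2ccc(O)cc2)c2ccccc2n1` differs from compound 2 in one place: 4-hydroxyphenyl in place of 2-chlorophenyl on a nitrogen on an aromatic ring. Among the measured compounds shown here, no measured pair shows this exchange, so its effect is unknown. The step is expected to be a 1.6-fold lower number from compound 2 to compound 3 (0.20 log units; within the scatter), at most slight and within the scatter, leaning toward a lower number. Compound 3 is estimated at 12000 nM, with a range from 4000 nM to 40000 nM.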

Compound 3, half-maximal inhibitory concentration: 8290 nM
Compound 3: middle estimate off by 1.4-fold (0.16 log units), on the high side; low and high end bracket the measured number.
By their numbers in this assay, from the lowest: compounds 1 and 3 (each within the scatter of the next); then compound 2.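

In this assay, placing 4-hydroxyphenyl instead of 2-chlorophenyl on the nitrogen gives a 2.3-fold lower number from compound 2 to compound 3 (0.36 log units; beyond the scatter), the first sign that the ring on this nitrogen can shift the read-out, though only modestly. Both groups hold the same number of heavy atoms, but the exchange replaces chlorine with a hydroxyl and also moves the substituent, so those two changes cannot be separated. Nothing available explains the step. Still open, from the compounds shown here alone, is how a ring carrying an amine or a carboxylic acid would behave at this nitrogen.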